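Chloro on the aromatic ring of compound 1: working notes

The source may hold more compounds than are shown below. What is called first, only, known or untested is meant among the compounds shown, and "the series" means these compounds.

- compound 1 `C/C=C(\C)[C@@H](O)[C@@H](C)[C@@H]1C/C=C(\C)C(=O)O[C@H](CC(C)C)C(=O)N[C@@H](C)C(=O)N(C)[C@H](Cc2ccccc2)C(=O)N(C)CC(=O)N[C@@H]([C@@H](C)CC)C(=O)N[C@H](C)C(=O)O1` gives 0.012 nM
- compound 2 `C/C=C(\C)[C@@H](O)[C@@H](C)[C@@H]1C/C=C(\C)C(=O)O[C@H](CC(C)C)C(=O)N[C@H](C)C(=O)N(C)[C@H](Cc2ccccc2)C(=O)N(C)CC(=O)N[C@@H]([C@@H](C)CC)C(=O)N[C@H](C)C(=O)O1` gives 925 nM

In a functional assay on K562 cells (Homo sapiens) for cytotoxicity, read by CellTiter-Blue, with a stated time of 72 h (a higher number here means a weaker inhibitor, a lower number a stronger inhibitor), compound 1 holds the lower of the two numbers, at 0.012 nM. Compound 3 `C/C=C(\C)[C@@H](O)[C@@H](C)[C@@H]1C/C=C(\C)C(=O)O[C@H](CC(C)C)C(=O)N[C@@H](C)C(=O)N(C)[C@H](Cc2ccc(Cl)cc2)C(=O)N(C)CC(=O)N[C@@H]([C@@H](C)CC)C(=O)N[C@H](C)C(=O)O1` differs from it by chloro in place of hydrogen on an aromatic carbon, which is chloro in place of hydrogen on an aromatic carbon, benzyl to 4-chlorobenzyl. Among the compounds with values here, the only measured step, a 77000-fold higher number from compound 1 to compound 2 (4.89 log units; beyond the scatter), is large, but it reflects (the fact that compounds 1 and 2 differ only in the configuration as drawn). It therefore gives no size for a chloro change. Little or no step beyond the scatter is expected in this assay, with any drift towards a higher number. The expected change is a 1.7-fold higher number from compound 1 to compound 3 (0.22 log units; within the scatter). For compound 3 the estimate is 0.02 nM, with an expected range of 0.003 nM to 0.15 nM.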

Compound 3, half-maximal inhibitory concentration: 0.000216 nM
Estimate against measurement, compound 3: 93-fold (1.97 log units) above, outside the stated range (below it).
By their numbers in this assay, from the lowest: compound 3; then compound 1; then compound 2.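

The 4-chlorobenzyl group shows that this aromatic position responds strongly to substitution: in this assay the change gives a 56-fold lower number from compound 1 to compound 3 (1.74 log units; beyond the scatter) and moves the series to a lower number. Within the data shown here, the earlier pair showed only a change of configuration, so this is the first measured size for a change on the aromatic ring. Nothing available here explains this step.

Whether the step is specific to chloro remains open, since bromo, fluoro, methyl and methoxy in the same place are absent from the compounds shown. Also open, going by these compounds, is whether chloro gives a similar step on the configuration of compound 2.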